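The source may report more compounds than this note shows. Statements on the series, on what has been measured and on what is new or still open speak of the compounds shown alone.

Working notes on the chalcone series, cytotoxicity arm.

Compound 1 `COc1ccc(C(=O)/C=C/c2ccc(C(=O)O)cc2)c(O)c1` is the reference point. In an ADME assay on SH-SY5Y cells (Homo sapiens) for cytotoxicity, read by MTT assay, with a stated time of 48 h (on this read-out lower numbers stand for stronger inhibition and higher numbers for weaker inhibition), compound 1 gives > 100000 nM, which is a limit of the assay and not a number. Two analogues have been run alongside it. Compound 3 `COC(=O)c1ccc(/C=C/C(=O)c2ccc(OC)cc2O)cc1` gives > 100000 nM in this assay, again a limit. Compound 2 `COc1ccc(C(=O)/C=C/c2ccc(OCCCOc3ccccc3)c(OC)c2)c(O)c1` gives > 100000 nM in this assay, also a limit. Going by the values given here, the only single-point step among the measured compounds is a step that the two limits leave unreadable from compound 1 to compound 3, and it cannot be read in either direction since both ends sit at the limit; the whole set rests on (the limit of > 100000 nM in this assay, at which 3 of the 3 values shown sit).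

Compound 4 `COc1ccc(C(=O)/C=C/c2ccc(C(=O)Nc3ccc(C)cc3C)cc2)c(O)c1` is the next member to be tested. It differs from compound 1 by (2,4-dimethylphenyl)amino in place of hydroxy on a carbonyl carbon. Among the compounds with values here, no measured step bears on this change in a readable way, so no size or direction can be drawn from the series; the only guidance is that every value so far sits at the limit. On that basis no step beyond the scatter is expected, and the step of a number no higher from compound 1 to compound 4 (the limit leaves the size open) is estimated to be nil. For compound 4 the estimate in this assay is 100000 nM, with a range from 30000 nM to 300000 nM, and a limit rather than a number is the more likely report.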

Compound 4, half-maximal inhibitory concentration: > 100000 nM
Compound 4: a limit, no number; the forecaster's own chance of this, stated with the estimate: 70%; the middle value lies on the limit itself.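

In this assay compound 4 gives > 100000 nM, a limit of the assay and not a number. Going by these compounds alone, the steps to compound 4 from compound 1 and from compound 3 cannot be read, so this result adds no new step. The compounds shown leave open how far any change on the carbonyl carbon moves the read-out, because all of them share one limit: the limit of > 100000 nM in this assay, at which 4 of the 4 values shown sit.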